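This account rests on a few compounds, and the source may have more. Where it says the series, first, only, none or still open, it means among the compounds named here.

Of the compounds shown here, three sharing one core have been tested in an ADME assay on PBMC cells (Homo sapiens) for cytotoxicity; on this read-out lower numbers stand for higher toxicity in this test and higher numbers for lower toxicity in this test. Compound 1 (`COc1cccc(OC(c2ccc(C(F)(F)F)cc2)C2CCN(C(C)CCNC(=O)c3c(Cl)cncc3Cl)CC2)n1`) gives 32700 nM, compound 2 (`CC(CCNC(=O)c1c(Cl)cncc1Cl)N1CCC(C(Oc2ccc(C(F)(F)F)cc2)c2ccc(C(F)(F)F)cc2)CC1`) gives 3100 nM, and compound 3 (`COC(=O)c1cccc(OC(c2ccc(C(F)(F)F)cc2)C2CCN(C(C)CCNC(=O)c3c(Cl)cncc3Cl)CC2)c1`) gives 15200 nM, the middle of the three numbers. Compound 4 (`CC(CCNC(=O)c1c(Cl)cncc1Cl)N1CCC(C(Oc2ccccc2Cl)c2ccc(C(F)(F)F)cc2)CC1`) has not yet been measured. It carries 2-chlorophenyl in place of 3-(methoxycarbonyl)phenyl on an oxygen on a saturated carbon.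

All three measured steps change the group at this place, so all bear on the new change. The nearest comparison is a 4.9-fold higher number from compound 2 to compound 3 (0.69 log units; beyond the scatter), a modest step that links 3-(methoxycarbonyl)phenyl with another phenyl group that has no ester. The other two steps show how far the number can move here: a 2.2-fold lower number from compound 1 to compound 3 (0.33 log units; beyond the scatter) is modest, while an 11-fold lower number from compound 1 to compound 2 (1.02 log units; beyond the scatter) is large. Among the measured compounds shown here, no compound with 2-chlorophenyl has been measured, so this comparison remains loose. With compound 2 at 3100 nM as the closest reference, a modest step to a lower number is expected in this assay. The estimated change is a 2.8-fold lower number from compound 3 to compound 4 (0.44 log units; beyond the scatter). For compound 4 the expected value is 5500 nM, with an estimated range of 2200 nM to 14000 nM.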

Compound 4, half-maximal cytotoxic concentration: 4400 nM
The estimate for compound 4 lay 1.3-fold (0.10 log units) above the measured number, within the range that was stated.
By their numbers in this assay, from the lowest: compounds 2 and 4 (each within the scatter of the next); then compound 3; then compound 1.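

In this assay, the step of a 3.5-fold lower number from compound 3 to compound 4 (0.54 log units; beyond the scatter) and the step of a 7.4-fold lower number from compound 1 to compound 4 (0.87 log units; beyond the scatter) both place 2-chlorophenyl at the low end of the numbers seen at this position, while the step of a 1.4-fold higher number from compound 2 to compound 4 (0.15 log units; within the scatter) lies within the scatter, so 2-chlorophenyl and 4-(trifluoromethyl)phenyl cannot be told apart here. Among the compounds shown here, the low numbers are therefore not tied to one substituent or to one place on the ring: across these four compounds, the two groups carrying a halogen-containing substituent give the low numbers and the two carrying a methoxy or methoxycarbonyl group give higher ones, with no compound going against this. Nothing shown accounts for this grouping, and with so few compounds it remains a description only.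

The compounds shown leave open how a plain phenyl with no substituent, a carboxylic acid in place of the methoxycarbonyl group, or an amine on the ring would compare on this oxygen. They also leave open whether the same ordering of these groups would hold if another part of the shared core were changed.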